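Replacing piperazin-1-yl in compound 2: a cytotoxicity estimate

The compounds below may be only part of what the source reports. "The series", "measured", "known", "first", "only" and "open" are said of these compounds alone.

In an ADME assay on CHO cells (Cricetulus griseus) for cytotoxicity, read by MTT assay (on this read-out higher numbers stand for lower toxicity in this test and lower numbers for higher toxicity in this test), compound 1 (`Fc1ccc(Nc2cc3[nH]c(Nc4ccc(N5CCNCC5)cn4)nc3cn2)cc1C(F)(F)F`) gives 14000 nM and compound 2 (`Fc1ccc(Nc2cc3[nH]c(Nc4cc(N5CCNCC5)ccn4)nc3cn2)cc1C(F)(F)F`) gives 31000 nM while compound 3 (`C[C@@H]1CN(c2ccc(Nc3nc4cnc(Nc5ccc(F)c(F)c5)cc4[nH]3)nc2)C[C@H](C)N1`) gives 2700 nM on the same read-out. Compound 2 thus holds the highest of the three numbers, and its distance from each of the other two lies beyond the usual scatter of such measurements.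

Compound 4 (`C[C@@H]1CN(C(=O)c2ccnc(Nc3nc4cnc(Nc5ccc(F)c(C(F)(F)F)c5)cc4[nH]3)c2)C[C@H](C)O1`) has not yet been measured. It differs from compound 2 at a single place, with (2,6-dimethylmorpholin-4-yl)carbonyl in place of piperazin-1-yl on an aromatic carbon. The new group stands on the same carbon of the six-membered aromatic ring with 1 nitrogen, opposite the ring nitrogen.

Within the data shown here, no pair of measured compounds shows a change of this kind, so the data give no direct guide to its size or direction in this assay and the best available anchor is compound 2 itself. With nothing to favour a larger move, the expected change (a 1.1-fold higher number from compound 2 to compound 4 (0.03 log units; within the scatter)) stays within the scatter. For compound 4 the estimated value is 33000 nM with an expected range from 10000 nM to 90000 nM in this test.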

Compound 4, half-maximal cytotoxic concentration: 30000 nM
Compound 4: middle estimate off by 1.1-fold (0.04 log units), on the high side; the measured number falls inside the stated range.
By their numbers in this assay, from the lowest: compound 3; then compound 1; then compounds 4 and 2 (each within the scatter of the next).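

In this assay, among these compounds, placing (2,6-dimethylmorpholin-4-yl)carbonyl in place of piperazin-1-yl on this aromatic carbon, opposite the ring nitrogen, gives a 1.0-fold lower number from compound 2 to compound 4 (0.01 log units; within the scatter) and provides the only direct reading of a change at this place. The entering group has more heavy atoms, a carbonyl, two defined stereocentres and no hydrogen-bond donor, whereas piperazin-1-yl has one, yet the two compounds remain within the scatter of each other in this test. Nothing at hand bears on why the two numbers agree.

A single pair cannot say whether other groups on this carbon, such as morpholin-4-yl joined without the carbonyl, a carboxylic acid or a simple dimethylamide, would also stay within the scatter of compound 2. The compounds shown also do not separate what the carbonyl and the two methyl groups each contribute, and they leave open whether the result would hold if the piperazin-1-yl of compound 1 were replaced in the same way.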